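Trimming a Cyclobutyl to Methyl on a Nitro-Bearing Core

The source may report more compounds than this note shows. Statements on the series, on what has been measured and on what is new or still open speak of the compounds shown alone.

Measured compounds in an assay on 1321N1 cells for antagonist activity at P2Y purinoceptor 6 (Homo sapiens), read by FLIPR and calcium flux; a higher number here means a weaker inhibitor, a lower number a stronger inhibitor:
- compound 1, `O=[N+]([O-])C1=Cc2cc(I)ccc2OC1C1CCC1`: 33100 nM
- compound 2, `CC[Si](C#Cc1cccc2c1C=C([N+](=O)[O-])C(C(F)(F)F)O2)(CC)CC`: 4770 nM
- compound 3, `O=[N+]([O-])C1=Cc2cc(C#Cc3ccc(CO)cc3)ccc2OC1C(F)(F)F`: 2000 nM

Three compounds share a fused two-ring core carrying a nitro group, and all three were tested in this assay. Compound 1 gives 33100 nM, the highest number of the three and therefore the weakest inhibitor in this set. The nearest value belongs to compound 2, which gives 4770 nM; the gap is well beyond the usual scatter. Compound 3 gives 2000 nM, further still. Compounds 2 and 3 differ from compound 1 in more than one place, so their stronger inhibition cannot be tied to any single group.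

Compound 4, `CC1Oc2ccc(I)cc2C=C1[N+](=O)[O-]`, has not yet been measured. It differs from compound 1 in one place only: methyl in place of cyclobutyl on a saturated ring carbon. Within the data shown here, no measured pair isolates this change, so there is no direct precedent for its effect. With a smaller group entering on the saturated ring carbon and the iodine and nitro group unchanged, a step from compound 1 to compound 4 that stays within the scatter is expected, with a slight lean toward a weaker inhibitor: a 1.2-fold higher number from compound 1 to compound 4 (0.08 log units; within the scatter). The estimated value for compound 4 in this assay is 40000 nM, with a likely range from 12000 nM to 130000 nM.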

Compound 4, half-maximal inhibitory concentration: 36800 nM
The estimate for compound 4 lay 1.1-fold (0.04 log units) above the measured number; low and high end bracket the measured number.
By their numbers in this assay, from the lowest: compound 3; then compound 2; then compounds 1 and 4 (each within the scatter of the next).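

In this assay, among these compounds, this pair gives the first comparison that isolates a single change, and methyl in place of cyclobutyl on the saturated ring carbon gives a 1.1-fold higher number from compound 1 to compound 4 (0.05 log units; within the scatter). With the iodine and nitro group held fixed, removing the four-membered ring and going from 4 heavy atoms to 1 at this position leaves a step within the scatter, so compound 1 and compound 4 cannot be told apart in this measurement. Nothing available explains why this change has so little effect on the number.

From the compounds shown here alone, the result covers only these two carbon groups on this one core, so it remains open whether a longer chain, an amine or a carboxylic acid at the same carbon would also leave the number in place. Going by these compounds, compound 2 and compound 3 differ from compound 1 and compound 4 in more than one place, so it also remains open whether the same change would have as little effect with a different group in place of the iodine.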